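Terminal Alkyne on a Long Trihydroxy Chain

A few compounds are considered here, and "the series" means these few. Any claim that something is new, unique, unknown or untested is made for them only; others in the source may bear on it.

Within the data shown here, compound 2 `C=CCCCCCCCCCCCC(O)CC(O)CO` gives the lowest of the two numbers so far in a functional assay on PC-3 cells (Homo sapiens) for cytotoxicity, read by MTT assay (on this read-out lower numbers stand for stronger inhibition and higher numbers for weaker inhibition), at 0.46 ug/mL. Compound 1 `CCCCCCCCCCCCCCCC(O)CC(O)CO` gives 1.2 ug/mL in this assay, and the step between them is a 2.6-fold lower number from compound 1 to compound 2 (0.42 log units; beyond the scatter). Compound 3 `C#CCCCCCCCCCCCC(O)CC(O)CO` is not yet measured; it differs from compound 2 by ethynyl in place of vinyl on a saturated chain carbon, ten or more bonds along the chain from an oxygen on a saturated carbon. Among the measured compounds shown here, the one measured step alters the same chain end, but describes another change, so nothing bears directly on this one. Compound 3 is therefore expected to move only slightly, the expected step being a 1.3-fold lower number from compound 2 to compound 3 (0.12 log units; within the scatter). The estimate for compound 3 in this assay is 0.35 ug/mL, with a range from 0.15 ug/mL to 0.9 ug/mL.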

Compound 3, half-maximal inhibitory concentration: 0.061 ug/mL
Beside the measured number, compound 3's estimate is 5.7-fold (0.76 log units) above it, and the stated range ends above it.
By their numbers in this assay, from the lowest: compound 3; then compound 2; then compound 1.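

In this assay, the kind of bond at the chain end matters with the count of heavy atoms unchanged: ethynyl in place of vinyl gives (a 7.5-fold lower number from compound 2 to compound 3 (0.88 log units; beyond the scatter)). Set against the saturated chain, ethynyl in place of butyl gives (a 20-fold lower number from compound 1 to compound 3 (1.29 log units; beyond the scatter)), so this position tolerates change and responds strongly to it in these three compounds. No evidence on hand accounts for this step.

Still open, going by these compounds, is how a nitrile at this chain end would read. On these data alone, it is also open whether a longer chain carrying the same ethynyl would keep the low number.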